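The compounds below may be only part of what the source reports. "The series", "measured", "known", "first", "only" and "open" are said of these compounds alone.

Measured compounds in a functional assay on HCT-116 cells (Homo sapiens) for antiproliferative activity, read by MTT assay, with a stated time of 48 h; on this read-out lower numbers stand for stronger inhibition of growth and higher numbers for weaker inhibition of growth:
Compound 1, `S=C(Nc1ccccc1)N1N=C(c2ccc(Br)cc2)CC1c1ccc2c(c1)OCCO2`: compound 1 gives 32100 nM.
Compound 2, `Cc1ccc(C2=NN(C(=S)Nc3ccccc3)C(c3ccc4c(c3)OCCO4)C2)cc1`: compound 2 reaches only a limit of the assay, > 200000 nM.
Compound 3, `COc1ccccc1C1=NN(C(=S)Nc2ccccc2)C(c2ccc3c(c2)OCCO3)C1`: compound 3 likewise reaches only a limit of the assay, > 200000 nM.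

Compound 3 therefore stands at the limit of > 200000 nM in this assay, at which 2 of the 3 values shown sit, with no number of its own. Compound 4, `S=C(Nc1ccccc1)N1N=C(c2ccc(Cl)c(Cl)c2)CC1c1ccc2c(c1)OCCO2`, differs from it by 3,4-dichlorophenyl in place of 2-methoxyphenyl on a carbon with a double bond to nitrogen. The readable steps, an at least 6.2-fold higher number from compound 1 to compound 2 (0.79 log units; beyond the scatter) and an at least 6.2-fold higher number from compound 1 to compound 3 (0.79 log units; beyond the scatter), both run from the halogen-bearing phenyl of compound 1 up to the limit, while a step that the two limits leave unreadable from compound 2 to compound 3 cannot be sized. Compound 4 brings back a halogen-bearing phenyl, so a return toward the value of compound 1, 32100 nM, is expected, meaning an at least 5.0-fold lower number from compound 3 to compound 4 (0.69 log units; beyond the scatter). For compound 4 the estimate is 40000 nM, with a range from 8000 nM to 200000 nM.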

Compound 4, concentration for 50% growth inhibition: 125000 nM
Compound 4: middle estimate off by 3.1-fold (0.49 log units), on the low side; measured number inside the range.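

At this position, on the carbon with a double bond to nitrogen, a halogen-bearing phenyl does not by itself carry the value of compound 1: 3,4-dichlorophenyl in place of 4-bromophenyl gives a 3.9-fold higher number from compound 1 to compound 4 (0.59 log units; beyond the scatter). Against the two earlier analogues, the change gives an at least 1.6-fold lower number from compound 3 to compound 4 (0.20 log units; that floor lies within the scatter) and an at least 1.6-fold lower number from compound 2 to compound 4 (0.20 log units; that floor lies within the scatter), so compound 4 is not clearly separated from either. Compound 2 and compound 3 remain limits, not numbers: the limit of > 200000 nM in this assay, at which 2 of the 4 values shown sit.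

Still open, on these data alone, is how a 4-chlorophenyl, or a phenyl bearing an amine or a carboxylic acid, would read at this position in this assay.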